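The source may report more compounds than this note shows. Statements on the series, on what has been measured and on what is new or still open speak of the compounds shown alone.

Three compounds share one core and differ only in what sits on the aromatic ring. Compound 1 `CC(C)Oc1ccccc1OC(C)C1=NCCN1` gives 0.5 in an assay on CHO cells with Alpha-2B adrenergic receptor (Homo sapiens) as the target; on this read-out lower numbers stand for smaller maximal responses and higher numbers for larger maximal responses. Compound 2 `C=COc1ccccc1OC(C)C1=NCCN1` gives 0.45 in this assay, and compound 3 `Cc1cccc(C)c1OC(C)C1=NCCN1` gives 0.8 in this assay. Compound 2 thus holds the lowest of the three numbers: its value and that of compound 1 lie within the scatter of each other, while compound 3 stands beyond the scatter above it. Compound 4 `CCc1ccccc1OC(C)C1=NCCN1` has not yet been measured. It differs from compound 2 in one place: ethyl in place of vinyloxy on an aromatic carbon. Among the measured compounds shown here, only one measured step exists, a number 0.050 lower from compound 1 to compound 2 (within the scatter), and it exchanges one group on the oxygen for another while keeping the oxygen, so it does not bear directly on taking the oxygen away. For the measured compounds named here, the closest guide is compound 3, whose substituents are carbon groups alone and which gives the higher number, but no single step links it to compound 2. Compound 4 is therefore expected to show a step of a number 0.20 higher from compound 2 to compound 4 (beyond the scatter), upward but uncertain. The estimated value for compound 4 is 0.65, within 0.45 to 0.85.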

Compound 4, intrinsic activity: the largest response reached, as a fraction of the reference agonist's: 0.5
Estimate against measurement, compound 4: 0.15 above; the measured number falls inside the stated range.
By their numbers in this assay, from the lowest: compounds 2, 1 and 4 (each within the scatter of the next); then compound 3.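

In this assay, this position on the aromatic ring tolerates loss of the oxygen that links the substituent: ethyl in place of vinyloxy gives a number 0.050 higher from compound 2 to compound 4 (within the scatter), and ethyl in place of isopropoxy gives no change at the digits printed from compound 1 to compound 4 (within the scatter). The earlier step changed only the group on that oxygen, whereas these two steps replace the whole oxygen-linked group, and neither moves the maximal response beyond the scatter. Nothing available here explains this result.

On these data alone, it remains open whether a different kind of group at this position, such as an amine, a carboxylic acid or a longer chain, would shift the response. Compound 3, at 0.8, differs from the other compounds in more than one place, so its value cannot be tied to any single change.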